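Hydroxy to Amino on Two Related Cores

This account rests on a few compounds, and the source may have more. Where it says the series, first, only, none or still open, it means among the compounds named here.

Measured compounds:
compound 1, `COc1ccccc1/C=C/c1ccccc1O`: 15 ug/mL
compound 2, `COc1ccccc1/C=C/c1ccccc1N`: 2.1 ug/mL
compound 3, `COc1cccc(/C=C/c2ccc(O)cc2)c1`: 24 ug/mL

These three were tested in an ADME assay on HEK293 cells (Homo sapiens) for inhibition, read by MTT assay, with a stated time of 2 days; on this read-out lower numbers stand for stronger inhibition and higher numbers for weaker inhibition. Compound 4, `COc1cccc(/C=C/c2ccc(N)cc2)c1`, has not yet been measured there. Compound 2 differs from compound 1 by amino in place of hydroxy on an aromatic carbon, and this single change gave a 7.1-fold lower number from compound 1 to compound 2 (0.85 log units; beyond the scatter). Compound 4 differs from compound 3 by amino in place of hydroxy on an aromatic carbon. The two changes are the same kind of change, not the same: in compound 1 the place is ortho to a large group, in compound 3 it is para to a large group. Compound 3 and compound 1 are built from the same atoms joined differently; the difference between the two cores is not broken down here. The value of compound 3 lies within the scatter of the value of compound 1, so both cores start from about the same level. On the second core the change is expected to give a step of similar size, a 4.8-fold lower number from compound 3 to compound 4 (0.68 log units; beyond the scatter), because of a 7.1-fold lower number from compound 1 to compound 2 (0.85 log units; beyond the scatter) on the first core, though the different place around the change leaves room for doubt. Compound 4 is therefore estimated at 5 ug/mL, most likely between 2 ug/mL and 12 ug/mL.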

Compound 4, half-maximal inhibitory concentration: 18 ug/mL
Compound 4: middle estimate off by 3.6-fold (0.56 log units), on the low side, and the stated range ends below it.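

In this assay, putting amino in place of hydroxy on an aromatic carbon, para to a large group, gave a 1.3-fold lower number from compound 3 to compound 4 (0.12 log units; within the scatter), so on this core the swap has no effect that can be told from ordinary assay noise. Within the data shown here, the same swap therefore did not carry over from one core to the other with the same size of step: the same change on two cores in this assay, a 7.1-fold lower number (0.85 log units; beyond the scatter) from compound 1 to compound 2 and a 1.3-fold lower number (0.12 log units; within the scatter) from compound 3 to compound 4, 5.4-fold (0.73 log units) apart, beyond the scatter of two such steps This shows that a large step on one core is a poor guide to the other, but with only one pair on each core it does not show whether the place of the change or the rest of the core sets the difference.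

As far as these compounds go, it remains open whether a methylamino or acetamido group in the same place would follow the amino group on either core. It is also unknown whether the gap between the two steps would appear in a different assay or cell type.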